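Swapping a Guanidine for a Methylpyrimidine on the Sulfonamide

The source may report more compounds than this note shows. Statements on the series, on what has been measured and on what is new or still open speak of the compounds shown alone.

Of the compounds shown here, three sharing one core have been measured in a functional assay on B16-F10 cells (Mus musculus) for cytotoxicity, read by CCK-8 assay, with a stated time of 48 h; a lower number here means a stronger inhibitor, a higher number a weaker inhibitor. Compound 3 `Cc1ccc2oc(=O)c(/C=N/c3ccc(S(=O)(=O)NC(=N)N)cc3)c(Cl)c2c1` gives 240 nM. Compound 1 `N=C(N)NS(=O)(=O)c1ccc(/N=C/c2c(Cl)c3ccccc3oc2=O)cc1` gives 180 nM, and compound 2 `Cc1ccc2oc(=O)c(/C=N/c3ccc(S(=O)(=O)Nc4nccs4)cc3)c(Cl)c2c1` gives 280 nM. Compound 3 thus holds the second highest of the three numbers, but this means little: the step of a 1.2-fold lower number from compound 2 to compound 3 (0.07 log units; within the scatter) lies within the scatter, as does a 1.3-fold higher number from compound 1 to compound 3 (0.12 log units; within the scatter), so all three numbers sit close together.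

Compound 4 `Cc1ccc2oc(=O)c(/C=N/c3ccc(S(=O)(=O)Nc4nccc(C)n4)cc3)c(Cl)c2c1` has not been measured. It differs from compound 3 in one place: a group of 7 heavy atoms (5 carbon, 2 nitrogen; one six-membered aromatic ring with 2 hetero atoms) in place of a group of 3 heavy atoms (1 carbon, 2 nitrogen; no ring), on a sulfonamide nitrogen. The step that bears most on this change is a 1.2-fold lower number from compound 2 to compound 3 (0.07 log units; within the scatter), where a ring group on the sulfonamide nitrogen was exchanged for the group that now leaves, with no change beyond the scatter. The step of a 1.3-fold higher number from compound 1 to compound 3 (0.12 log units; within the scatter) concerns a different position and shows only how little the numbers move within this set. Putting a different ring group back onto the sulfonamide nitrogen is therefore expected to move the number little, and the expected step is a 1.1-fold higher number from compound 3 to compound 4 (0.05 log units; within the scatter). Compound 4 is estimated at 270 nM, in a range from 130 nM to 560 nM.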

Compound 4, half-maximal inhibitory concentration: 270 nM
Estimate against measurement, compound 4: no gap at the digits printed; the measured number falls inside the stated range.
By their numbers in this assay, from the lowest: compounds 1, 3, 4 and 2 (each within the scatter of the next).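

On the sulfonamide nitrogen in this assay, the group with no ring, 2 hydrogen-bond donors and 1 hydrogen-bond acceptor gives way to 4-methylpyrimidin-2-yl, with one six-membered aromatic ring and 0 hydrogen-bond donors, in a 1.1-fold higher number from compound 3 to compound 4 (0.05 log units; within the scatter), so even this larger change in size and donor count leaves no readable difference. Exchanging one aromatic ring for another at the same place, 4-methylpyrimidin-2-yl in place of 1,3-thiazol-2-yl, gives a 1.0-fold lower number from compound 2 to compound 4 (0.02 log units; within the scatter), and the three groups now seen on this nitrogen therefore cannot be told apart by this read-out. No measurement here explains why such different groups give matching numbers.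

Going by these compounds, what remains open is whether any group on this nitrogen can take the number beyond the scatter, for example a plain hydrogen, a methyl, or a longer chain ending in an amine or a carboxylic acid. On these data alone, it is also open whether 4-methylpyrimidin-2-yl would give the same picture on the core of compound 1, which has a hydrogen where compound 3 carries its methyl on an aromatic carbon.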